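Amide nitrogen substituent and maximal response in the series

This account rests on a few compounds, and the source may have more. Where it says the series, first, only, none or still open, it means among the compounds named here.

Three measured compounds share one core and differ only in the group on the amide-type nitrogen. Compound 1 `CCN(Cc1ccccc1C(F)(F)F)C(=O)C1CCN(S(=O)(=O)c2ccc3[nH]ncc3c2)CC1` gives 96% in a functional assay on CHO cells for positive allosteric modulation of muscarinic acetylcholine receptor M5 (Homo sapiens), read by calcium flux; on this read-out higher numbers stand for larger maximal responses and lower numbers for smaller maximal responses. Compound 2 `CCCN(Cc1ccccc1C(F)(F)F)C(=O)C1CCN(S(=O)(=O)c2ccc3[nH]ncc3c2)CC1` gives 94% in this assay, a step of a number 2 percentage points lower from compound 1 to compound 2 (within the scatter). Compound 3 `CC(C)N(Cc1ccccc1C(F)(F)F)C(=O)C1CCN(S(=O)(=O)c2ccc3[nH]ncc3c2)CC1` gives 54% in this assay and stands lowest of the three numbers, separated from compound 2 by a number 40 percentage points lower from compound 2 to compound 3 (beyond the scatter) and from compound 1 by a number 42 percentage points lower from compound 1 to compound 3 (beyond the scatter).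

Compound 4 `O=C(C1CCN(S(=O)(=O)c2ccc3[nH]ncc3c2)CC1)N(Cc1ccccc1C(F)(F)F)C1CCC1` is not yet measured. It differs from compound 3 by cyclobutyl in place of isopropyl on an amide-type nitrogen. Among the measured compounds shown here, no measured pair shows an exchange of one branched group for another; the two large steps, from compound 1 and compound 2 to compound 3, only show what follows when a straight chain on that nitrogen is exchanged for isopropyl, while the step from compound 1 to compound 2 lies within the scatter. Cyclobutyl, like the isopropyl it replaces, is not a straight chain, so no step beyond the scatter is expected in this assay for the exchange, in either direction.

Compound 4 is therefore expected to reach about 55% in this assay, within 35% to 80%, a step of a number 1 percentage points higher from compound 3 to compound 4 (within the scatter) that is estimated to stay within the scatter.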

Compound 4, largest response reached (reported as percent of maximum), in percent of the reference or control that the assay uses: 84%
Compound 4: middle estimate off by 29 percentage points, on the low side; measured number above the stated range.
By their numbers in this assay, from the lowest: compound 3; then compounds 4, 2 and 1 (each within the scatter of the next, the first and the last beyond it).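

Cyclobutyl in place of isopropyl on the amide-type nitrogen gives a number 30 percentage points higher from compound 3 to compound 4 (beyond the scatter) in this assay and so shows that the low response of compound 3 is not shared by every group other than a straight chain at this position. Set against the straight chains, the picture differs by partner: cyclobutyl in place of propyl gives a number 10 percentage points lower from compound 2 to compound 4 (within the scatter) and cyclobutyl in place of ethyl gives a number 12 percentage points lower from compound 1 to compound 4 (beyond the scatter) in the same series, so compound 4 lies much nearer the straight-chain compounds than compound 3 without fully matching compound 1. Nothing available on these compounds explains the difference between isopropyl and cyclobutyl at this nitrogen.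

Open, on these data alone, is how cyclopropyl, cyclopentyl or tert-butyl on this nitrogen would compare with isopropyl and cyclobutyl, and whether a longer chain such as butyl would stay level with ethyl and propyl. Also open, as far as these compounds go, is whether the gap between isopropyl and cyclobutyl would persist with a group other than trifluoromethyl on the aromatic ring of the shared core.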